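Swapping 4-methylbenzyl for acetyl on a ring amine

The source may hold more compounds than are shown below. What is called first, only, known or untested is meant among the compounds shown, and "the series" means these compounds.

Measured in a physicochemical assay for solubility, with a stated time of 3 days, at pH 7; on this read-out higher numbers stand for higher solubility and lower numbers for lower solubility:
compound 1 `CN1CCC(Oc2ccc(-c3nc4cc(C(N)=O)ccc4[nH]3)cc2)CC1`: > 400000 nM
compound 2 `Cc1ccc(CN2CCCCC2CCOc2ccc(-c3nc4cc(C(N)=O)ccc4[nH]3)cc2)cc1`: 97000 nM
compound 3 `NC(=O)c1ccc2[nH]c(-c3ccc(OCCC4CCN(Cc5ccccc5)CC4)cc3)nc2c1`: 5000 nM

Only two of these entries are true numbers. Of those two, compound 2 at 97000 nM stands highest, and compound 3 at 5000 nM lies lower by a gap beyond the usual scatter of repeat measurements.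

Still unmeasured is compound 4 `CC(=O)N1CCCCC1CCOc1ccc(-c2nc3cc(C(N)=O)ccc3[nH]2)cc1`. It differs from compound 2 in one place: acetyl in place of 4-methylbenzyl on an amine nitrogen in a ring.

Among the compounds with values here, no measured pair shows this exchange on its own, so any expectation is indirect. Compound 1, with no aromatic ring on that nitrogen, gives > 400000 nM, which is a limit of the assay and not a number. Going by that one compound, a rise in this assay beyond the scatter is expected, though compound 1 also differs in other parts of its structure. The expected change is a 2.3-fold higher number from compound 2 to compound 4 (0.36 log units; beyond the scatter). For compound 4 the estimate is 220000 nM, with an expected range from 70000 nM to 600000 nM.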

Compound 4, solubility: 193000 nM
For compound 4 the middle estimate is 1.1-fold (0.06 log units) above the measured one; measured number inside the range.
By their numbers in this assay, from the lowest: compound 3; then compounds 2 and 4 (each within the scatter of the next). At a limit, above all of these: compound 1.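

In this assay, the exchange at this ring nitrogen can now be read directly, with the rest of the molecule unchanged: a 2.0-fold higher number from compound 2 to compound 4 (0.30 log units; within the scatter). The step stays within the usual scatter of repeat measurements, so this single pair does not separate 4-methylbenzyl, which carries a six-membered aromatic ring of carbon only, from acetyl, which has no ring and carries a hydrogen-bond acceptor. Compound 1 could not show this, since it differs from compound 2 in more than one place and its reading is a limit and not a number: the limit of > 400000 nM in this assay, at which 1 of the 4 values shown sits.

On these data alone, whether a urea or a methanesulfonyl group on this same nitrogen would read differently from acetyl remains open. Also open, as far as these compounds go, is whether the exchange of 4-methylbenzyl for acetyl would give a step of similar size in a compound built like compound 3, where the ring nitrogen and the chain are arranged differently, as a single pair cannot show whether the result carries over to other compounds.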